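Carbamate in Place of Benzyl on a Geranyl-Bearing Core

The source may report more compounds than this note shows. Statements on the series, on what has been measured and on what is new or still open speak of the compounds shown alone.

Compound 1, `CC(C)=CCC1Cc2c(OCc3ccccc3)cc(=O)n(CCCO)c2CC1(C)C`: -0.3%
Compound 2, `CC(C)=CCC1Cc2c(OC(=O)Nc3ccc(F)c(F)c3)cc(=O)n(CCCO)c2CC1(C)C`: 76.7%
Compound 3, `CC(C)=CCC/C(C)=C/CC1Cc2c(OCc3ccccc3)cc(=O)n(CCCO)c2CC1(C)C`: 46.5%

These three compounds were tested in a functional assay on PANC-1 cells (Homo sapiens) for inhibition, read by MTT assay, with a stated time of 24 h, tested at 10 uM; a lower number here means less inhibition, a higher number more inhibition at the concentration tested (going by the name of the read-out). Compound 3 stands second highest of the three numbers; compound 2 lies above it, beyond the scatter, and compound 1 lies below it, also beyond the scatter. Compound 3 differs from compound 1 only by the longer chain on the shared core, and that change alone gave a number 46.8 percentage points higher from compound 1 to compound 3 (beyond the scatter).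

Compound 4, `COc1cccc(NC(=O)Oc2cc(=O)n(CCCO)c3c2CC(C/C=C(\C)CCC=C(C)C)C(C)(C)C3)c1`, keeps the long chain of compound 3 and changes the group on the ring oxygen: (3-methoxyphenyl)carbamoyl in place of benzyl on an oxygen on an aromatic ring

Among the compounds with values here, the step that bears on this is the one from compound 1 to compound 2, where a carbamoyl group replaced benzyl on the same oxygen and gave a number 77 percentage points higher from compound 1 to compound 2 (beyond the scatter), a large rise. The same kind of replacement is made here, on a compound that already starts higher, so a rise beyond the scatter is expected, though the number in this assay cannot go much higher than where compound 2 already stands. Compound 4 is therefore estimated at 82%, within 60% to 96%, which means an expected step of a number 35.5 percentage points higher from compound 3 to compound 4 (beyond the scatter).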

Compound 4, a percentage reported as inhibition, at one concentration (the size of the read-out at that concentration, not a potency): 47%
The estimate for compound 4 lay 35 percentage points above the measured number, outside the stated range (below it).
By their numbers in this assay, from the lowest: compound 1; then compounds 3 and 4 (each within the scatter of the next); then compound 2.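

In this assay, putting (3-methoxyphenyl)carbamoyl in place of benzyl on this oxygen of the longer-chain compound changes nothing that can be told from the scatter (a number 0.5 percentage points higher from compound 3 to compound 4 (within the scatter)). A carbamoyl group here therefore does not always bring a rise, since the large step seen earlier (a number 77 percentage points higher from compound 1 to compound 2 (beyond the scatter)) does not recur, although that step involved (3,4-difluorophenyl)carbamoyl and the shorter chain. No measurement at hand explains this difference between the two steps.

The compounds shown leave open whether the chain or the substituents on the carbamoyl phenyl ring separate these two outcomes, a question that needs both carbamoyl groups compared on one chain. On these data alone, how an amine or a carboxylic acid on that phenyl ring would read also stays open.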